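The source may hold more compounds than are shown below. What is called first, only, known or untested is meant among the compounds shown, and "the series" means these compounds.

In a functional assay on the whole organism with Rattus norvegicus as the target (a higher number here means that more compound is needed for the effect, a lower number that less compound is needed), compound 1 `N#CNC(=N)NCCCCn1nc(-c2ccccc2)ccc1=O` gives 59.3 mg/kg, the lowest of the three numbers measured, though neither neighbour sits beyond the scatter: compound 2 `C/N=C(/NC#N)NCCCn1nc(-c2ccccc2)ccc1=O` gives 78.1 mg/kg and compound 3 `CN(C)/C(=N/CCCn1nc(-c2ccccc2)ccc1=O)NC#N` gives 93.1 mg/kg, with a 1.3-fold higher number from compound 1 to compound 2 (0.12 log units; within the scatter) and a 1.2-fold higher number from compound 2 to compound 3 (0.08 log units; within the scatter). Compound 4 `CN(C)/C(=N/CCCCn1nc(-c2ccccc2)ccc1=O)NC#N` differs from compound 1 by a group of 8 heavy atoms (4 carbon, 4 nitrogen; no ring) in place of a group of 6 heavy atoms (2 carbon, 4 nitrogen; no ring), on a saturated chain carbon, four bonds along the chain from an aromatic nitrogen. The step that bears most directly on this change is a 1.6-fold higher number from compound 1 to compound 3 (0.20 log units; within the scatter), which likewise exchanged the cyanoguanidine bearing hydrogens for its dimethyl form, on a chain one carbon shorter, and stayed within the scatter. One therefore expects at most a small rise in this assay, a 1.4-fold higher number from compound 1 to compound 4 (0.16 log units; within the scatter), and estimates compound 4 at 85 mg/kg, between 50 mg/kg and 145 mg/kg.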

Compound 4, dose for half-maximal effect: 52.9 mg/kg
The estimate for compound 4 lay 1.6-fold (0.21 log units) above the measured number; low and high end bracket the measured number.
By their numbers in this assay, from the lowest: compounds 4, 1, 2 and 3 (each within the scatter of the next).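

In this assay, the group of 8 heavy atoms in place of the group of 6 heavy atoms, on a saturated chain carbon, four bonds along the chain from an aromatic nitrogen, gives a 1.1-fold lower number from compound 1 to compound 4 (0.05 log units; within the scatter) and so stays within the scatter. At this place, going from 3 hydrogen-bond donors to 1 hydrogen-bond donor thus leaves the number unmoved beyond the scatter. No measurement at hand speaks to why this is so.

From the compounds shown here alone, whether a piperidine, a carboxylic acid or a longer chain at this place would move the number beyond the scatter remains open.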